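Swapping a Fluorophenyl for an Ester on the Shared Core

The source may hold more compounds than are shown below. What is called first, only, known or untested is meant among the compounds shown, and "the series" means these compounds.

Compound 2 `O=C(NCc1ccc(F)cc1)c1nc(Br)c2cccnc2c1NCc1ccc(F)cc1` was tested in a functional assay on HCT-116 cells (Homo sapiens) for cytotoxicity, read by MTT assay, with a stated time of 72 h; a higher number here means a weaker inhibitor, a lower number a stronger inhibitor. In this assay compound 2 gives only a limit of the assay, > 20000 nM, and no number. Compound 1 `N[C@H]1CC[C@H](Nc2c(C(=O)NCc3ccc(F)cc3)nc(N3CCCCS3(=O)=O)c3cccnc23)CC1`, built on the same core with other groups, also gives only a limit, > 10000 nM. Both results shown are therefore limits, the limit of > 10000 nM in this assay, at which 1 of the 2 values shown sits, and (the limit of > 20000 nM in this assay, at which 1 of the 2 values shown sits), so compound 2 stands among compounds with no measurable inhibition in this assay. Compound 3 `COC(=O)CNc1c(C(=O)NCc2ccc(F)cc2)nc(Br)c2cccnc12` is not yet measured. It differs from compound 2 in one place: methoxycarbonyl in place of 4-fluorophenyl on a saturated chain carbon bound to a nitrogen on an aromatic ring. Going by the values given here, no step between measured compounds is available to size this change. With both measured compounds sitting at a limit, the expected step that the limit leaves unreadable from compound 2 to compound 3 is none beyond the scatter. Compound 3 is estimated at 30000 nM, within 10000 nM to 100000 nM, and is expected most likely to be reported only as a limit again.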

Compound 3, half-maximal inhibitory concentration: > 10000 nM
Compound 3: no number, only a limit; the forecaster's own chance of this, stated with the estimate: 80%; the middle value lies beyond the limit too.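

Going by these compounds alone, compound 2 and compound 3 both give only limits in this assay, so no step between them can be read. The compounds shown leave open whether methoxycarbonyl in place of 4-fluorophenyl changes anything in this assay, and what a measured number on the shared core would be.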